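Isopropyl for Cyclopropyl Carried onto a Second Core

A few compounds are considered here, and "the series" means these few. Any claim that something is new, unique, unknown or untested is made for them only; others in the source may bear on it.

The study concerns three measured compounds and one that has not yet been measured. Compound 1 `COc1cc(N(CC2CC2)c2ccc(F)c3ccccc23)cnc1C(=O)[C@H]1C[C@@H]1C(=O)O` and compound 2 `COc1cc(N(CC(C)C)c2ccc(F)c3ccccc23)cnc1C(=O)[C@H]1C[C@@H]1C(=O)O` share one core; compound 3 `COc1cc(N(CC2CC2)c2cccc(C(F)(F)F)c2)cnc1C(=O)[C@H]1C[C@@H]1C(=O)O` and compound 4 `COc1cc(N(CC(C)C)c2cccc(C(F)(F)F)c2)cnc1C(=O)[C@H]1C[C@@H]1C(=O)O` share another. The difference between the two cores is not broken down here.

In an assay on isolated protein for inhibition of leukotriene C4 synthase (Homo sapiens), read by LC-MS, with stated times of 45 min and 20 min (on this read-out lower numbers stand for stronger inhibition and higher numbers for weaker inhibition), compound 1 gives 26.5 nM, compound 2 gives 2.26 nM and compound 3 gives 52.4 nM. The numbers of compound 1 and compound 3 lie within the usual scatter of each other, while compound 2 lies well below both, beyond the scatter.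

Compound 2 differs from compound 1 in one place. isopropyl in place of cyclopropyl on a saturated chain carbon bound to a nitrogen on an aromatic ring This single change gave a 12-fold lower number from compound 1 to compound 2 (1.07 log units; beyond the scatter).

Compound 4 differs from compound 3 in the same way, at the same kind of position. isopropyl in place of cyclopropyl on a saturated chain carbon bound to a nitrogen on an aromatic ring Since the place is described in identical words, this is the same change carried onto the second core, and it occurs twice among the compounds shown.

On the strength of the step from compound 1 to compound 2, a step of similar direction is expected for compound 4, though the second core has only compound 3 as its anchor, so some caution is warranted. The expected step from compound 3 to compound 4 in this assay is estimated as a 6.6-fold lower number from compound 3 to compound 4 (0.82 log units; beyond the scatter). For compound 4 the estimate in this assay is 8 nM, with a likely range from 2.5 nM to 25 nM.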

Compound 4, half-maximal inhibitory concentration: 20.6 nM
The estimate for compound 4 lay 2.6-fold (0.41 log units) below the measured number; measured number inside the range.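

In this assay, the direction of the change carried over to the second core: isopropyl in place of cyclopropyl on a saturated chain carbon bound to a nitrogen on an aromatic ring gave a 2.5-fold lower number from compound 3 to compound 4 (0.41 log units; beyond the scatter) and so again lowered the number, beyond the scatter. The size of the step did not carry over, and the two steps differ by more than the scatter allows: the same change on two cores in this assay, a 12-fold lower number (1.07 log units; beyond the scatter) from compound 1 to compound 2 and a 2.5-fold lower number (0.41 log units; beyond the scatter) from compound 3 to compound 4, 4.6-fold (0.66 log units) apart, beyond the scatter of two such steps. Among the compounds shown here, this shows that, for these two pairs, the change pointed the same way while its gain depended on the core, so the step from one core could not be transferred to the other as a fixed amount; it does not show which part of the core difference governs the size of the step, nor does it establish a rule for the series, since only two pairs carry the change and both were read in a single assay.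

The compounds shown leave open how large the step would be on a third core, and whether the trend would extend to other groups at the same place. A cyclobutyl group or a longer straight chain such as n-propyl, on a saturated chain carbon bound to a nitrogen on an aromatic ring, would test whether isopropyl is unusual or simply one point in a wider trend.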